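The source may hold more compounds than are shown below. What is called first, only, known or untested is meant among the compounds shown, and "the series" means these compounds.

Working notes on the series. Compound 2 `CC(C(=O)NCc1ccc(C(F)(F)F)nc1C1=CCC(C(C)(C)C)CC1)c1ccc(NS(C)(=O)=O)c(F)c1` holds the lower of the two numbers seen so far: in an assay on CHO cells for antagonist activity at transient receptor potential cation channel subfamily V member 1 (Homo sapiens), read by FLIPR and calcium flux (on this read-out lower numbers stand for stronger inhibition and higher numbers for weaker inhibition), compound 2 gives 0.2 nM. Compound 1 `C[C@H](C(=O)NCc1ccc(C(F)(F)F)nc1C1CC2CCC1C2)c1ccc(NS(C)(=O)=O)c(F)c1`, drawn with an S centre at the saturated chain carbon and a different ring on the shared core, gives 0.8 nM in this assay. Compound 3 `C[C@H](C(=O)NCc1ccc(C(F)(F)F)nc1C1=CCC(C(C)(C)C)CC1)c1ccc(NS(C)(=O)=O)c(F)c1` shares all atoms and bonds with compound 2; the change is the two compounds have the same atoms and bonds; at least one stereo element is drawn with a configuration in one of them and without one in the other: 1 of 2 stereo elements differ; a stereocentre at a saturated chain carbon is drawn without a configuration in compound 2 and S in compound 3. Since compound 1 with its S centre reaches 0.8 nM, the S form appears well tolerated. For compound 3 the expected step is a 1.3-fold lower number from compound 2 to compound 3 (0.12 log units; within the scatter), toward a lower number or none beyond the scatter. Compound 3 is estimated at 0.15 nM, within 0.05 nM to 0.5 nM.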

Compound 3, inhibition constant: 0.1 nM
Beside the measured number, compound 3's estimate is 1.5-fold (0.18 log units) above it; measured number inside the range.
By their numbers in this assay, from the lowest: compounds 3 and 2 (each within the scatter of the next); then compound 1.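

With the S centre drawn in both, the group of 10 heavy atoms in place of the group of 7 heavy atoms gives a step beyond the scatter in this assay, an 8.0-fold lower number from compound 1 to compound 3 (0.90 log units; beyond the scatter), so the ring on the shared core matters more here than the drawn configuration. Defining the centre gives only a 2.0-fold lower number from compound 2 to compound 3 (0.30 log units; within the scatter), and this step has a limit to its reading: the fact that one of compounds 2 and 3 is drawn with a defined configuration and the other without, at the place where they differ.

The compounds shown leave open how the R form compares. Also open, going by these compounds, is whether an amine or a carboxylic acid on that six-membered ring is tolerated.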